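The source may report more compounds than this note shows. Statements on the series, on what has been measured and on what is new or still open speak of the compounds shown alone.

Working notes on the series.

Compound 1 `CC(C)(C)[C@H]1CC[C@]2(CC1)N=C(c1cccc(C(F)(F)F)c1)C(=O)N2Cc1ccc(C(=O)NCCC(=O)O)cc1` carries a 3-(trifluoromethyl)phenyl group on the imine carbon of the shared core. In an assay on membranes from liver for displacement of a labelled ligand from Glucagon receptor (Mus musculus), read by scintillation counting, with a stated time of 60 min (on this read-out lower numbers stand for stronger inhibition and higher numbers for weaker inhibition), compound 1 gives 10000 nM, the highest of the two numbers reported in this set. The nearest comparison is compound 3 `C[C@H](c1ccc(C(=O)NCCC(=O)O)cc1)N1C(=O)C(c2cccc(Cl)c2F)=N[C@]12CC[C@@H](C(C)(C)C)CC2`, which gives 4000 nM, a number lower than that of compound 1 and beyond the scatter. Compound 2 `C[C@H](c1ccc(C(=O)NCCC(=O)O)cc1)N1C(=O)C(c2ccccc2F)=N[C@]12CC[C@@H](C(C)(C)C)CC2` is reported only as a limit, > 10000 nM, and not as a number. For the measured compounds named here, the one measured step that can be sized is an at least 2.5-fold lower number from compound 2 to compound 3 (0.39 log units; beyond the scatter); the limit noted as the limit of > 10000 nM in this assay, at which 1 of the 3 values shown sits, means its true size is not fixed.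

Compound 4 `CC(C)(C)[C@H]1CC[C@]2(CC1)N=C(c1ccc(Cl)cc1)C(=O)N2Cc1ccc(C(=O)NCCC(=O)O)cc1` is compound 1 changed by 4-chlorophenyl in place of 3-(trifluoromethyl)phenyl on a carbon with a double bond to nitrogen. Going by the values given here, no measured step covers a swap of this kind, since the step from compound 2 to compound 3 adds a chloro to an existing aryl rather than exchanging one aryl for another. It does show that a chloro-bearing aryl on the imine carbon can sit at a lower number, so for compound 4 a step of a 1.4-fold lower number from compound 1 to compound 4 (0.15 log units; within the scatter) in this assay is expected, at best modest and with wide uncertainty. Compound 4 is therefore estimated at 7000 nM, within 2000 nM to 25000 nM.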

Compound 4, half-maximal inhibitory concentration: > 10000 nM
Compound 4: only a limit was reported; the forecaster's own chance of this, stated with the estimate: 35%; middle value at least 1.4-fold (0.15 log units) from the limit.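

On the carbon with a double bond to nitrogen, 4-chlorophenyl in place of 3-(trifluoromethyl)phenyl gives a number no lower from compound 1 to compound 4 (the limit leaves the size open) in this assay, so a second aryl group at this position gives no readable gain. A chloro on the aryl group is therefore not enough by itself to give a lower number here, even though chloro in place of hydrogen gave an at least 2.5-fold lower number from compound 2 to compound 3 (0.39 log units; beyond the scatter); that step was taken on a different aryl group. The size of the change from compound 1 to compound 4 cannot be read because the value of compound 4 is a limit: the limit of > 10000 nM in this assay, at which 2 of the 4 values shown sit.

Going by these compounds, how far compound 4 lies from compound 1 stays open, and so does whether the 4-chlorophenyl group is merely equal to the 3-(trifluoromethyl)phenyl group or worse than it. Also open, on these data alone, is how this position responds to other groups, such as a methoxy group or a nitrile on the aryl ring, or an amine in place of the aryl group.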